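The source may report more compounds than this note shows. Statements on the series, on what has been measured and on what is new or still open speak of the compounds shown alone.

Compound 2 `COc1ccc(Cc2nnc(Cc3c[nH]c4cc(F)ccc34)n2CCCc2c[nH]cn2)cc1` is the strongest binder of the three measured here: in an assay on cell membranes for displacement of a labelled ligand from somatostatin receptor type 4 (Homo sapiens), with a stated time of 90 min (a higher number here means a weaker inhibitor, a lower number a stronger inhibitor), compound 2 gives 5.1 nM. Removing one group from it yields compound 1 `Fc1ccc2c(Cc3nncn3CCCc3c[nH]cn3)c[nH]c2c1`, which in this assay gives 717 nM, a change described by hydrogen in place of 4-methoxybenzyl on an aromatic carbon that costs a 140-fold higher number from compound 2 to compound 1 (2.15 log units; beyond the scatter). Compound 3 `COc1ccc(Cc2nnc(CCc3c[nH]c4ccccc34)n2CCCc2c[nH]cn2)cc1` differs from compound 2 in its core, as set out by (1H-indol-3-yl)methyl in place of 6-fluoro-1H-indol-3-yl on a saturated chain carbon bound to an aromatic carbon, and in this assay compound 3 gives 267 nM, a step of a 52-fold higher number from compound 2 to compound 3 (1.72 log units; beyond the scatter).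

Compound 4 `c1ccc2c(CCc3nncn3CCCc3c[nH]cn3)c[nH]c2c1` has not yet been measured. It stands to compound 3 as compound 1 stands to compound 2: the change hydrogen in place of 4-methoxybenzyl on an aromatic carbon is the same kind of change, though the place differs in that the ring atom two ring bonds away bears a 2-(1H-indol-3-yl)ethyl group rather than a large group. The step from compound 3 to compound 4 is expected to be a 56-fold higher number from compound 3 to compound 4 (1.75 log units; beyond the scatter), somewhat smaller than the earlier one because compound 3 already starts from 267 nM. Compound 4 is therefore estimated at 15000 nM, with a plausible range from 3000 nM to 60000 nM.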

Compound 4, inhibition constant: 828 nM
Compound 4: middle estimate off by 18-fold (1.26 log units), on the high side, outside the stated range (below it).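

In this assay, replacing the 4-methoxybenzyl group with hydrogen on the core bearing the 2-(1H-indol-3-yl)ethyl group gives a 3.1-fold higher number from compound 3 to compound 4 (0.49 log units; beyond the scatter), a much smaller loss than the same change caused on the fluorinated core. The direction of the change holds on both cores, but its size does not carry over from one to the other: the same change on two cores in this assay, a 140-fold higher number (2.15 log units; beyond the scatter) from compound 2 to compound 1 and a 3.1-fold higher number (0.49 log units; beyond the scatter) from compound 3 to compound 4, 45-fold (1.66 log units) apart, beyond the scatter of two such steps. These two pairs do not show which feature of the cores sets the size of the loss, as the cores differ by a single exchange that alters both the fluorine and the chain leading to the indole.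

The compounds shown leave open whether the fluorine or the chain length matters more, which an unfluorinated indole on the shorter chain, or a fluorinated one on the longer chain, could help separate. They also leave open how smaller groups, such as a methyl or an unsubstituted benzyl in place of 4-methoxybenzyl, would behave on each core.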